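Permeability notes: naphthyl replacing methoxyphenoxy on the shared core

A few compounds are considered here, and "the series" means these few. Any claim that something is new, unique, unknown or untested is made for them only; others in the source may bear on it.

Two compounds of the series have numbers in an ADME assay for permeability, using PAMPA, with a stated time of 30 min, at pH 7.4; a lower number here means that the compound crosses the layer more slowly, a higher number that the compound crosses the layer faster. Compound 1, `Cc1cc(C)cc(Cc2ccc3c(NCCCNCc4ccco4)ccnc3c2)c1`, gives 23 10^-6 cm/s in this assay. Within the data shown here, compound 2, `COc1ccc(Oc2ccc3c(NCCCNCc4ccco4)ccnc3c2)cc1`, gives 317 10^-6 cm/s in this assay and so stands highest of the two numbers, with compound 1 as its only neighbour; the one step measured, a 14-fold higher number from compound 1 to compound 2 (1.14 log units; beyond the scatter), is large and beyond the scatter. The next compound, compound 3, `c1coc(CNCCCNc2ccnc3cc(-c4cccc5ccccc45)ccc23)c1`, is not yet measured. Its change from compound 2 is naphthalen-1-yl in place of 4-methoxyphenoxy on an aromatic carbon. Among the measured compounds shown here, the only step that bears on it is the one between compound 1 and compound 2, and it shows how strongly this position of the core moves the number. With the 4-methoxyphenoxy group gone, the number for compound 3 is expected to fall again in this assay, the estimated step being a 4.5-fold lower number from compound 2 to compound 3 (0.66 log units; beyond the scatter). Compound 3 is therefore expected to give about 70 10^-6 cm/s, within 20 10^-6 cm/s to 220 10^-6 cm/s.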

Compound 3, apparent permeability: 237 10^-6 cm/s
Estimate against measurement, compound 3: 3.4-fold (0.53 log units) below; measured number outside the range, above it.
By their numbers in this assay, from the lowest: compound 1; then compounds 3 and 2 (each within the scatter of the next).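

In this assay, naphthalen-1-yl in place of 4-methoxyphenoxy on this aromatic carbon gives a 1.3-fold lower number from compound 2 to compound 3 (0.13 log units; within the scatter) and so leaves the two compounds indistinguishable, even though compound 3 lacks the 2 oxygen atoms of the leaving group. Among the three compounds, only compound 1, with 3,5-dimethylbenzyl, stands apart: the change to naphthalen-1-yl gives a 10-fold higher number from compound 1 to compound 3 (1.01 log units; beyond the scatter) and so matches the large step to the 4-methoxyphenoxy compound, a 14-fold higher number from compound 1 to compound 2 (1.14 log units; beyond the scatter). No supporting data are available to explain why these two different groups give numbers within the scatter of each other.

Going by these compounds, the three compounds differ only at this one aromatic carbon, so the effect of a change elsewhere on the shared core remains open. On these data alone, it also remains open whether an amine or a carboxylic acid at this carbon would give a number near that of compound 3 or near that of compound 1.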